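Sulfonamide nitrogen substituents on a shared core

This account rests on a few compounds, and the source may have more. Where it says the series, first, only, none or still open, it means among the compounds named here.

Measured so far:
- compound 1, `CNS(=O)(=O)c1ccc2c(c1)C(n1ccccc1=O)=CC(C)(C)O2`: 17.8 nM
- compound 2, `CC1(C)C=C(n2ccccc2=O)c2cc(S(=O)(=O)NCCO)ccc2O1`: 110 nM

In a functional assay with Rattus norvegicus as the target (on this read-out lower numbers stand for an effect already at smaller amounts and higher numbers for an effect only at larger amounts of compound), compound 2 shows the higher of the two numbers. Compound 3, `CC1(C)C=C(n2ccccc2=O)c2cc(S(=O)(=O)NC(=O)Nc3ccccc3)ccc2O1`, carries phenylcarbamoyl in place of 2-hydroxyethyl on a sulfonamide nitrogen. Among the measured compounds shown here, the only step bearing on this position is a 6.2-fold higher number from compound 1 to compound 2 (0.79 log units; beyond the scatter), where adding to the sulfonamide nitrogen raised the number. A larger group there is therefore expected to raise it further, though the data for such a group are thin. For compound 3 the expected step is a 2.7-fold higher number from compound 2 to compound 3 (0.44 log units; beyond the scatter), giving an estimated 300 nM with a range from 60 nM to 1500 nM.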

Compound 3, half-maximal effective concentration: 1410 nM
Estimate against measurement, compound 3: 4.7-fold (0.67 log units) below, within the range that was stated.
By their numbers in this assay, from the lowest: compound 1; then compound 2; then compound 3.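

In this assay, putting phenylcarbamoyl in place of 2-hydroxyethyl on the sulfonamide nitrogen gives a 13-fold higher number from compound 2 to compound 3 (1.11 log units; beyond the scatter), and putting it in place of methyl gives a 79-fold higher number from compound 1 to compound 3 (1.90 log units; beyond the scatter). Across these three compounds, the number rises with each larger group, and this change moves it further than the earlier step did. No measurement shown offers an explanation for this rise. From the compounds shown here alone, the aromatic ring and the carbonyl enter together, so their separate contributions remain open. A benzyl group, with the ring alone, or an acetyl group, with the carbonyl alone, would help to separate them.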